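This account rests on a few compounds, and the source may have more. Where it says the series, first, only, none or still open, it means among the compounds named here.

Of the compounds shown here, three on the shared core have so far been read in a functional assay on MCF7 cells (Homo sapiens) for inhibition, read by MTT assay, with a stated time of 72 h; on this read-out lower numbers stand for stronger inhibition and higher numbers for weaker inhibition. Compound 1 `O=C1C=C[C@@H](OC2CCCC2)O[C@@H]1CO` gives 20700 nM there, compound 2 `CC(C)O[C@@H]1C=CC(=O)[C@@H](CO)O1` gives 36000 nM and compound 3 `C#CCO[C@@H]1C=CC(=O)[C@@H](CO)O1` gives 10400 nM there. Compound 3 sits close to one neighbour and apart from the other, with a 2.0-fold lower number from compound 1 to compound 3 (0.30 log units; within the scatter) but a 3.5-fold lower number from compound 2 to compound 3 (0.54 log units; beyond the scatter) on the other side. Compound 4 `C=CCO[C@@H]1C=CC(=O)[C@@H](CO)O1` differs from compound 3 by vinyl in place of ethynyl on a saturated chain carbon bound to an oxygen on a saturated carbon. Among the compounds with values here, no measured step makes this exchange. Within the data shown here, the nearest guides are the swaps on that same oxygen, those two steps and the one between compound 1 and compound 2 (a 1.7-fold higher number from compound 1 to compound 2 (0.24 log units; within the scatter)), and none of them is large. A small rise in this assay, not beyond the scatter, is therefore expected, the estimated step being a 1.4-fold higher number from compound 3 to compound 4 (0.16 log units; within the scatter) in size. Compound 4 is estimated at 15000 nM (7000 nM to 32000 nM).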

Compound 4, half-maximal inhibitory concentration: 16300 nM
Estimate against measurement, compound 4: 1.1-fold (0.04 log units) below; the range from low to high includes it.
By their numbers in this assay, from the lowest: compounds 3, 4, 1 and 2 (each within the scatter of the next, the first and the last beyond it).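

In this assay, vinyl in place of ethynyl on a saturated chain carbon gives a 1.6-fold higher number from compound 3 to compound 4 (0.20 log units; within the scatter), so on the shared core the triple bond is not needed to hold a number in this range. Allyl also stays within the scatter of cyclopentyl, with a 1.3-fold lower number from compound 1 to compound 4 (0.10 log units; within the scatter), but separates from isopropyl, with a 2.2-fold lower number from compound 2 to compound 4 (0.34 log units; beyond the scatter); this matches the propargyl compound, though saturated cyclopentyl, within the scatter of all three other groups, goes against any simple link to unsaturation. No evidence is available to explain these steps.

From the compounds shown here alone, whether a benzyl group, a longer chain or an amine-bearing chain on this oxygen would move the number further remains open.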